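The source may hold more compounds than are shown below. What is called first, only, known or untested is meant among the compounds shown, and "the series" means these compounds.

In a functional assay on PC-3 cells (Homo sapiens) for cytotoxicity, read by MTT assay, with a stated time of 72 h (on this read-out lower numbers stand for stronger inhibition and higher numbers for weaker inhibition), compound 2 `Cc1ccc(S(=O)(=O)c2nc3ccccc3nc2N2CCCC(O)C2)cc1` gives 5330 nM. Going by the values given here, that is the only number recorded for the two measured compounds. Compound 1 `COc1ccc(S(=O)(=O)c2nc3ccccc3nc2N2CCCC2)cc1` is reported in this assay only as a limit, > 50000 nM, not as a number. the limit of > 50000 nM in this assay, at which 1 of the 2 values shown sits, marks where that limit sits. Compound 1 differs from compound 2 in two places at once, so the pair cannot be read as a single step.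

Compound 3 `COc1ccc(S(=O)(=O)c2nc3ccccc3nc2N2CCCC(O)C2)cc1` has not yet been measured. It differs from compound 2 in one place only: methoxy in place of methyl on an aromatic carbon. Among the compounds with values here, no measured pair shows this exact change on its own, so the size of the step is uncertain. Compound 1 carries the same methoxy group and reaches only the limit > 50000 nM in this assay, though its amine ring also differs. On that basis the step of a 2.8-fold higher number from compound 2 to compound 3 (0.45 log units; beyond the scatter) is expected to lie beyond the usual scatter, toward weaker inhibition. Compound 3 is therefore expected to give about 15000 nM in this assay, within a range from 4000 nM to 50000 nM, with a real chance that only a limit is returned.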

Compound 3, half-maximal inhibitory concentration: 3410 nM
The estimate for compound 3 lay 4.4-fold (0.64 log units) above the measured number; the whole stated range lies above it.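

In this assay, replacing 4-methylphenyl with 4-methoxyphenyl gives a 1.6-fold lower number from compound 2 to compound 3 (0.19 log units; within the scatter), so on this aromatic carbon, para to a large group, the two groups cannot be told apart in this pair. With the 4-methoxyphenyl group held fixed, 3-hydroxypiperidin-1-yl in place of pyrrolidin-1-yl gives an at least 14-fold lower number from compound 1 to compound 3 (1.16 log units; beyond the scatter), which places the large difference in this pair at the amine ring and shows that the methoxy group does not by itself bring the weak result seen for compound 1. For compound 1 the reading is a limit, not a number: the limit of > 50000 nM in this assay, at which 1 of the 3 values shown sits.

The ring change alters both the ring size and the presence of a hydroxyl group, and only a plain piperidin-1-yl group or a 3-hydroxypyrrolidin-1-yl group in the same place would show which of the two goes with the step. As far as these compounds go, it also remains open how far this aromatic position tolerates change, since a group such as a carboxylic acid, an amine or a longer alkoxy chain there could behave quite differently from methyl and methoxy.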